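Inverting one ring stereocentre of compound 1

The source may report more compounds than this note shows. Statements on the series, on what has been measured and on what is new or still open speak of the compounds shown alone.

Measured in a functional assay on KB cells (Homo sapiens) for cytotoxicity, read by colorimetric assay and neutral red uptake, with a stated time of 72 h; on this read-out higher numbers stand for weaker inhibition and lower numbers for stronger inhibition:
- compound 1 `CO[C@@H](C(=O)N[C@H]1CCCCNC1=O)[C@@H]1OC(C)(C)O[C@H](/C=C/C(C)(C)C)[C@@H]1O`: > 150000 nM (a limit)
- compound 2 `CO[C@@H](C(=O)N[C@H]1CC[C@@H](O)CNC1=O)[C@H](O)[C@@H](O)[C@H](O)/C=C/C(C)(C)C`: 62600 nM
- compound 3 `CO[C@@H](C(=O)N[C@H]1CC[C@H](O)CNC1=O)[C@H](O)[C@@H](O)[C@H](O)/C=C/C(C)(C)C`: 19800 nM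

Compound 1 stands at the limit of > 150000 nM in this assay, at which 1 of the 3 values shown sits, and so has no number to start from. Compound 4 `CO[C@@H](C(=O)N[C@@H]1CCCCNC1=O)[C@@H]1OC(C)(C)O[C@H](/C=C/C(C)(C)C)[C@@H]1O` differs from it by the two compounds have the same atoms and bonds and differ only in configuration as drawn: 1 of 6 stereo elements differ; a stereocentre at a saturated ring carbon is drawn S in compound 1 and R in compound 4 (a stereocentre at a saturated ring carbon is drawn S in compound 1 and R in compound 4). For the measured compounds named here, the only measured step of this kind is a 3.2-fold lower number from compound 2 to compound 3 (0.50 log units; beyond the scatter), which goes with the fact that compounds 2 and 3 differ only in the configuration as drawn and belongs to a different pair. Its direction therefore does not carry over, and a step of that modest size is the most that seems reasonable. The expected step is a number no higher from compound 1 to compound 4 (the limit leaves the size open), which means none beyond the scatter. For compound 4 the estimate is 150000 nM, with an expected range of 50000 nM to 300000 nM, and a further limit is likely.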

Compound 4, half-maximal inhibitory concentration: > 150000 nM
Compound 4 was reported as a limit (the forecaster's own chance of this, stated with the estimate: 65%); the middle value lies on the limit itself.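

Compound 1 and compound 4 are both reported only as limits in this assay, so no step can be read between them. The compounds shown leave open whether inverting this ring stereocentre changes the read-out at all.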